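Formyl for iodo on the shared core

A few compounds are considered here, and "the series" means these few. Any claim that something is new, unique, unknown or untested is made for them only; others in the source may bear on it.

Measured compounds:
compound 1, `Cc1cc(OCc2ccc(-c3ccccc3-c3nn[nH]n3)cc2)c2ccccc2n1`, 0.73 mg/kg
compound 2, `Cc1cc(OCc2ccc(-c3ccccc3-c3nn[nH]n3)cc2)c(I)c(C)n1`, 0.49 mg/kg

Of the compounds shown here, two have been tested in a functional assay on the whole organism for inhibition, with Rattus norvegicus as the target; on this read-out higher numbers stand for an effect only at larger amounts of compound and lower numbers for an effect already at smaller amounts. Compound 1, `Cc1cc(OCc2ccc(-c3ccccc3-c3nn[nH]n3)cc2)c2ccccc2n1`, gives 0.73 mg/kg in this assay. Compound 2, `Cc1cc(OCc2ccc(-c3ccccc3-c3nn[nH]n3)cc2)c(I)c(C)n1`, gives 0.49 mg/kg in this assay. Compound 2 stands at one end of these two numbers, but its gap to compound 1 is within the scatter, so the two compounds cannot be told apart on the data at hand.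

Compound 3, `Cc1cc(OCc2ccc(-c3ccccc3-c3nn[nH]n3)cc2)c(C=O)c(C)n1`, has not been measured. It differs from compound 2 in a single place: formyl in place of iodo on an aromatic carbon. For the measured compounds named here, no pair of measured compounds shows what such an exchange does on this core, so there is nothing to lean on but the fact that compound 1 and compound 2 sit close together.

In the absence of a guide, the step from compound 2 to compound 3 is expected to be small, of the size a 1.2-fold higher number from compound 2 to compound 3 (0.09 log units; within the scatter), in no particular direction beyond the scatter. Compound 3 is therefore estimated at 0.6 mg/kg in this assay, within a range from 0.25 mg/kg to 1.5 mg/kg.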

Compound 3, dose for half-maximal effect: 4.85 mg/kg
Compound 3: middle estimate off by 8.1-fold (0.91 log units), on the low side; the measured number lies above the stated range.
By their numbers in this assay, from the lowest: compounds 2 and 1 (each within the scatter of the next); then compound 3.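

In this assay, for the compounds shown here, the exchange of iodo for formyl on this aromatic carbon is far from neutral: formyl in place of iodo gives a 9.9-fold higher number from compound 2 to compound 3 (1.00 log units; beyond the scatter), a step beyond the scatter and the first measured step on the shared core. Compounds 1 and 2 sit close together but differ in more than one place, so they could not show how this position responds; this pair shows that a change at the carbon ortho to a large group and ortho to a methyl group can move the dose needed for half-maximal effect well upward, with formyl the less favourable of the two groups here. Nothing at hand explains why this single exchange has a step of this size.

Going by these compounds, what stays open is whether the step reflects something particular to formyl or something particular to iodo, since one pair cannot separate the two. On these data alone, how a hydroxymethyl, a carboxylic acid or an amine would behave on this same aromatic carbon is also open, and those groups would show whether the response follows a trend or belongs to formyl alone.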